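The source may hold more compounds than are shown below. What is called first, only, known or untested is meant among the compounds shown, and "the series" means these compounds.

Measured so far: compound 1, `O=C(Nc1ccccc1O)C1CCc2ccccc2N1C(=O)c1ccccc1Cl`, gives 47400 nM in a functional assay on MDA-MB-231 cells (Homo sapiens) for cytotoxicity, read by sulforhodamine B assay, with a stated time of 72 h; a lower number here means a stronger inhibitor of growth, a higher number a weaker inhibitor of growth. Compound 2, `O=C(Nc1ccccc1O)C1CCc2ccccc2N1C(=O)c1ccc(Cl)cc1`, gives 19600 nM in this assay. Compound 3, `CC(=O)N1c2ccccc2CCC1C(=O)Nc1cc(C(F)(F)F)cc(C(F)(F)F)c1`, gives > 70000 nM in this assay; this is a limit of the assay, not a number, and compound 3 therefore sits at the limit of > 70000 nM in this assay, at which 1 of the 3 values shown sits.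

Compound 4, `O=C(Nc1cc(C(F)(F)F)cc(C(F)(F)F)c1)C1CCc2ccccc2N1C(=O)c1cccc(Cl)c1`, differs from compound 3 in one place: 3-chlorophenyl in place of methyl on a carbonyl carbon. Among the measured compounds shown here, no measured step changes an acetyl to an aroyl group, so no step bears directly on this change. For the measured compounds named here, the only measured step, a 2.4-fold lower number from compound 1 to compound 2 (0.38 log units; beyond the scatter), moves the chlorine on an aroyl group that compound 4 also carries, and it is modest. Compound 1 and compound 2, both bearing an aroyl group, give numbers in this assay, while compound 3, bearing acetyl, gives only a limit; the amide aryl differs between them, so this is not a step.

For compound 4 he therefore expects a lower number than the limit of compound 3, the step of an at least 2.3-fold lower number from compound 3 to compound 4 (0.36 log units; beyond the scatter) being an estimate only. He estimates for compound 4 in this assay a value of 30000 nM, between 10000 nM and 90000 nM.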

Compound 4, concentration for 50% growth inhibition: 1190 nM
The estimate for compound 4 lay 25-fold (1.40 log units) above the measured number; measured number outside the range, below it.
By their numbers in this assay, from the lowest: compound 4; then compound 2; then compound 1. At a limit, above all of these: compound 3.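

In this assay, the change from acetyl to (3-chlorophenyl)carbonyl on this carbonyl carbon gives an at least 58-fold lower number from compound 3 to compound 4 (1.76 log units; beyond the scatter), a large step and larger than the only earlier one, a 2.4-fold lower number from compound 1 to compound 2 (0.38 log units; beyond the scatter). That earlier step moved a chlorine within an aroyl group, whereas this one shows that replacing the methyl itself can turn a limit into a measured number. The value of compound 3 is a limit of the assay and not a number, so this step is a bound and not an exact size: the limit of > 70000 nM in this assay, at which 1 of the 4 values shown sits.

The compounds shown do not tell whether the added ring or its chlorine carries the step, and an unsubstituted phenyl, a pyridine or a longer alkyl chain on this carbonyl carbon remains untested here. Compound 4 also differs from compound 1 and compound 2 in more than one place, so the share of the bis(trifluoromethyl)phenyl amide cannot be read.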